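The compounds below may be only part of what the source reports. "The series", "measured", "known", "first", "only" and "open" are said of these compounds alone.

Measured so far in a functional assay on HepG2 cells (Homo sapiens) for inhibition, with a stated time of 72 h; on this read-out higher numbers stand for weaker inhibition and lower numbers for stronger inhibition:
- compound 1 `O=C(Nc1ccccc1)Nc1nc(Sc2c[nH]c3ccccc23)cc(N2CCCC2)n1`: 11400 nM
- compound 2 `O=C(Nc1ccc(Cl)cc1)Nc1nc(Sc2c[nH]c3ccccc23)cc(N2CCCCC2)n1`: 14800 nM

Compound 2 gives 14800 nM and compound 1 gives 11400 nM. These two values lie within the usual scatter of each other, so compound 2 cannot be ranked against compound 1 on this read-out.

The next compound to be measured is compound 3 `O=C(Nc1ccccc1)Nc1nc(Sc2c[nH]c3ccccc23)cc(N2CCCCC2)n1`. It comes from compound 2 through one structural change, hydrogen in place of chloro on an aromatic carbon, para to a large group, which turns 4-chlorophenyl into phenyl: hydrogen in place of chloro on an aromatic carbon.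

For the measured compounds named here, no two measured compounds differ in one place only, so the series holds no direct measure of this change. Going by the values given here, nothing measured so far points to a step of any particular direction, and none beyond the scatter is expected in this assay. The estimated change, a 1.1-fold lower number from compound 2 to compound 3 (0.06 log units; within the scatter), is expected to stay within that scatter. The expected value for compound 3 is 13000 nM, with an estimated range of 6000 nM to 28000 nM.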

Compound 3, half-maximal inhibitory concentration: 20900 nM
For compound 3 the middle estimate is 1.6-fold (0.21 log units) below the measured one; the measured number falls inside the stated range.
By their numbers in this assay, from the lowest: compounds 1, 2 and 3 (each within the scatter of the next).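

In this assay hydrogen in place of chloro on an aromatic carbon, para to a large group, now has a direct reading: a 1.4-fold higher number from compound 2 to compound 3 (0.15 log units; within the scatter) shows that 4-chlorophenyl and phenyl cannot be told apart on this read-out. For the compounds shown here, compound 3 also gives the first direct reading at the other variable place, where piperidin-1-yl in place of pyrrolidin-1-yl on an aromatic carbon gives a 1.8-fold higher number from compound 1 to compound 3 (0.26 log units; within the scatter) and so does not separate these two groups either. No measurement is available that bears on the size of either step.

As far as these compounds go, each change has been read only once, so it remains open whether chloro and hydrogen would also stay within the scatter of each other with pyrrolidin-1-yl in place of piperidin-1-yl. From the compounds shown here alone, it also remains open whether a methoxy group or a carboxylic acid on the phenyl ring, or morpholin-4-yl in place of piperidin-1-yl, would move the number beyond the scatter.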